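This account rests on a few compounds, and the source may have more. Where it says the series, first, only, none or still open, it means among the compounds named here.

Working notes on the series. Compound 1 `COc1c(N2CC[C@@H](CN)C2)c(F)cc2c(=O)c(C(=O)O)cn(Cc3ccc(-c4ccccc4)cc3)c12` carries a cyclic side chain on the shared core; in an assay on isolated protein for inhibition of DNA topoisomerase 1 (Homo sapiens), with a stated time of 15 min (a higher number here means a weaker inhibitor, a lower number a stronger inhibitor), compound 1 gives 26000 nM. Compound 2 `CNCCNc1cc2c(cc1F)c(=O)c(C(=O)O)cn2Cc1ccc(-c2ccccc2)cc1` bears an open chain in that position instead. In this assay compound 2 returns only > 200000 nM, which is a limit of the assay and not a number. Compound 2 thus stands at the limit of > 200000 nM in this assay, at which 1 of the 2 values shown sits. Within the data shown here, no step between measured compounds can be read here; the two values shown differ only in that compound 1 gives a number while compound 2 gives a limit.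

Compound 3 `CNCCCNc1cc2c(cc1F)c(=O)c(C(=O)O)cn2Cc1ccc(-c2ccccc2)cc1` is not yet measured. It differs from compound 2 by (methylamino)methyl in place of methylamino on a saturated chain carbon, two bonds along the chain from a nitrogen on an aromatic ring. The expected step of a number no higher from compound 2 to compound 3 (the limit leaves the size open) is none beyond the scatter. Compound 3 is estimated at 200000 nM, with a range from 60000 nM to 700000 nM, and most likely only a limit is again reported.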

Compound 3, half-maximal inhibitory concentration: 63600 nM
For compound 3 the middle estimate is 3.1-fold (0.50 log units) above the measured one; low and high end bracket the measured number.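

In this assay, (methylamino)methyl in place of methylamino on a saturated chain carbon, two bonds along the chain from a nitrogen on an aromatic ring, gives an at least 3.1-fold lower number from compound 2 to compound 3 (0.49 log units; beyond the scatter), so this position of the open chain responds to a change of a single carbon. With compound 3 the open chain now has a measured number, which compound 2 did not give. The true size of the step remains unknown, since the value for compound 2 is a limit and not a number: the limit of > 200000 nM in this assay, at which 1 of the 3 values shown sits.

As far as these compounds go, whether a still longer chain, such as 4-(methylamino)butyl, or a primary amine or dimethylamino group at the chain end would shift the number further remains open. Compound 1 differs from compound 3 in more than one place, so the two cannot be compared directly.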